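From a limit towards a measurable value

The source may hold more compounds than are shown below. What is called first, only, known or untested is meant among the compounds shown, and "the series" means these compounds.

Compound 1 `COc1cc([C@@H]2C[C@]2(CO)C(=O)Nc2ccccc2Cl)cc(OC)c1OC` gives 16900 nM
Compound 2 `CCOC(=O)C1(C(=O)Nc2ccccc2Cl)CC1c1cc(OC)c(OC)c(OC)c1` gives 41400 nM; 14200 nM (2 entries)
Compound 3 `CCOC(=O)[C@]1(C(=O)NCc2ccc(C)cc2)C[C@H]1c1cc(OC)c(OC)c(OC)c1` gives > 100000 nM

All three compounds were tested in a functional assay on K562 cells (Homo sapiens) for cytotoxicity, read by MTT assay, with a stated time of 48 h (a lower number here means a stronger inhibitor, a higher number a weaker inhibitor), and the question is what a single change on the amide will do. Compound 3 stands at > 100000 nM in this assay and this is a limit of the assay, not a number. A further entry for compound 3 gives no single number either, which leaves the starting point without an exact value.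

Compound 4 `CCOC(=O)[C@]1(C(=O)Nc2ccccc2Cl)C[C@H]1c1cc(OC)c(OC)c(OC)c1` has not been measured yet. Its difference from compound 3 is 2-chlorophenyl in place of 4-methylbenzyl on an amide-type nitrogen with 2-chlorophenyl in place of 4-methylbenzyl on an amide-type nitrogen.

For the measured compounds named here, no measured pair of compounds shows this change directly, so the expectation rests on neighbours that carry the same 2-chlorophenyl group. Compound 1 has that group and gives 16900 nM as a real number. Compound 2 has it too and gives 41400 nM; 14200 nM (2 entries) in two entries that do not coincide (the several entries of compound 2 in this assay, 41400 nM; 14200 nM (2 entries)) and this calls for a wide range.

From the compounds shown here alone, the expected step of an at least 5.0-fold lower number from compound 3 to compound 4 (0.69 log units; beyond the scatter) points to a lower number and a stronger inhibitor, though its exact size stays open. The estimated value for compound 4 is 20000 nM (expected range 7000 nM to 60000 nM).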

Compound 4, half-maximal inhibitory concentration: 20700 nM
Beside the measured number, compound 4's estimate is 1.0-fold (0.01 log units) below it; the measured number falls inside the stated range.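

In this assay, 2-chlorophenyl in place of 4-methylbenzyl on the amide-type nitrogen takes the compound from a limit to a real number, with an at least 4.8-fold lower number from compound 3 to compound 4 (0.68 log units; beyond the scatter). From the compounds shown here alone, this shows that the group on this nitrogen matters, but the step gives only a minimum size, and the true gap stays unknown: the limit of > 100000 nM in this assay, at which 1 of the 4 values shown sits. With 2-chlorophenyl held on the nitrogen, ethoxycarbonyl and hydroxymethyl on the saturated ring carbon cannot be told apart, with a 1.2-fold higher number from compound 1 to compound 4 (0.09 log units; within the scatter).

The amide change replaces benzyl with phenyl and methyl with chlorine in a single step, so a 2-chlorobenzyl or 4-methylphenyl group on the same nitrogen, or a carboxylic acid on the saturated ring carbon, remains an open case. Compound 4 carries the same groups as compound 2, which gives 41400 nM; 14200 nM (2 entries), and what the defined configuration contributes cannot be read from these values: the fact that one of compounds 2 and 4 is drawn with a defined configuration and the other without, at the place where they differ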